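Para substituent exchange on the shared core

A few compounds are considered here, and "the series" means these few. Any claim that something is new, unique, unknown or untested is made for them only; others in the source may bear on it.

Measured compounds:
compound 1 `O=C(Nc1ccc(Cl)cc1)C(Cl)Cl`, 60800 nM
compound 2 `O=C(Nc1ccc(I)cc1)C(Cl)Cl`, 66200 nM

In a functional assay on KB cells (Homo sapiens) for antiproliferative activity, read by MTT assay, with a stated time of 72 h (a lower number here means a stronger inhibitor, a higher number a weaker inhibitor), compound 1 gives 60800 nM and compound 2 gives 66200 nM. Compound 2 sits alongside compound 1, the step being a 1.1-fold higher number from compound 1 to compound 2 (0.04 log units; within the scatter). Compound 3 `COc1ccc(NC(=O)C(Cl)Cl)cc1` differs from compound 2 by methoxy in place of iodo on an aromatic carbon. Among the compounds with values here, the only measured step at this position, a 1.1-fold higher number from compound 1 to compound 2 (0.04 log units; within the scatter), swaps one halogen for another and stayed within the scatter; no measured step exchanges a halogen for methoxy. The expectation is therefore no step beyond the scatter, a 1.0-fold lower number from compound 2 to compound 3 (0.01 log units; within the scatter). Compound 3 is estimated at 65000 nM, range 25000 nM to 170000 nM.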

Compound 3, half-maximal inhibitory concentration: 278000 nM
The estimate for compound 3 lay 4.3-fold (0.63 log units) below the measured number, outside the stated range (above it).
By their numbers in this assay, from the lowest: compounds 1 and 2 (each within the scatter of the next); then compound 3.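

In this assay, the substituent on this aromatic carbon does matter, which the halogen exchange alone did not show: methoxy in place of iodo gives a clear step (a 4.2-fold higher number from compound 2 to compound 3 (0.62 log units; beyond the scatter)), and methoxy in place of chloro gives one of similar size (a 4.6-fold higher number from compound 1 to compound 3 (0.66 log units; beyond the scatter)). Both steps run towards a weaker inhibitor. Nothing measured bears on the origin of these steps.

From the compounds shown here alone, it remains open whether an amine or a longer chain such as ethoxy at this position would stay with the halogens or follow methoxy. Going by these compounds, whether the step is particular to methoxy also remains open.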